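The source may hold more compounds than are shown below. What is called first, only, known or untested is meant among the compounds shown, and "the series" means these compounds.

Compound 1 `FC(F)(F)c1cccc(-c2nc3cnc(Nc4ccccn4)cc3[nH]2)c1` and compound 2 `FC(F)(F)c1cccc(-c2nc3cnc(Nc4ncccn4)cc3[nH]2)c1` share one core and differ only at a nitrogen on an aromatic ring. Among the measured compounds shown here, in a physicochemical assay for solubility, using the shake flask method, measured as kinetic solubility, with a stated time of 20 h, at pH 2 (a higher number here means a more soluble compound, a lower number a less soluble compound), compound 1 gives 21000 nM, the lower of the two numbers measured so far, and compound 2 gives 155000 nM. For the measured compounds named here, the single measured step is a 7.4-fold higher number from compound 1 to compound 2 (0.87 log units; beyond the scatter). Compound 3 `FC(F)(F)c1cccc(-c2nc3cnc(Nc4cccnn4)cc3[nH]2)c1` has not yet been measured in this assay. It differs from compound 1 in one place: pyridazin-3-yl in place of pyridin-2-yl on a nitrogen on an aromatic ring. The step from compound 1 to compound 2 bears on this change, since it likewise replaces pyridin-2-yl at the same place with a six-membered aromatic ring with two hetero atoms, and it was modest and beyond the scatter. A step of the same direction and roughly similar size is therefore expected, a 3.8-fold higher number from compound 1 to compound 3 (0.58 log units; beyond the scatter), although pyridazin-3-yl is not pyrimidin-2-yl and the size is uncertain. Compound 3 is estimated at 80000 nM, with a range from 25000 nM to 250000 nM.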

Compound 3, solubility: 161000 nM
The estimate for compound 3 lay 2.0-fold (0.30 log units) below the measured number, and the stated range covers the measured number.
By their numbers in this assay, from the lowest: compound 1; then compounds 2 and 3 (each within the scatter of the next).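

In this assay the change to pyridazin-3-yl gives a 7.7-fold higher number from compound 1 to compound 3 (0.88 log units; beyond the scatter) and so repeats, with a second six-membered aromatic ring with 2 hetero atoms, the direction already seen in a 7.4-fold higher number from compound 1 to compound 2 (0.87 log units; beyond the scatter) on the same nitrogen. The new comparison is a 1.0-fold higher number from compound 2 to compound 3 (0.02 log units; within the scatter) and it lies within the scatter, so the pyrimidin-2-yl and pyridazin-3-yl groups cannot be told apart in this read-out, and both stand apart from pyridin-2-yl. Nothing measured here accounts for this result.

The compounds shown leave open how a triazinyl ring, a saturated ring such as piperidinyl, or a carboxylic acid on the pyridine ring would fare at this nitrogen. They also leave open whether the same steps would appear with a group other than trifluoromethyl on the far phenyl ring.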